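The source may report more compounds than this note shows. Statements on the series, on what has been measured and on what is new or still open speak of the compounds shown alone.

Three compounds of the series carry numbers in a functional assay on PC-3 cells (Homo sapiens) for antiproliferative activity, read by MTT assay, tested at 5 uM; a higher number here means a stronger effect of the compound at the concentration tested, a lower number a weaker effect. Compound 1 `COc1cc(C(=O)N/N=C/c2ccc(F)c(F)c2)cc(OC)c1OC` gives 43.7%, and compound 3 `COc1cc(C(=O)N/N=C/c2ccccc2C(F)(F)F)cc(OC)c1OC` gives 52.9%. Compound 2 `COc1cc(C2=NN(C(C)=O)C(c3c(Cl)cccc3Cl)O2)cc(OC)c1OC` gives -2.2%, the lowest of the three numbers; its gap to compound 1 and its larger gap to compound 3 both lie beyond the usual scatter, so compound 2 stands clearly apart from the other two as the weakest here. Among the compounds with values here, compounds 1 and 3 share the same hydrazone linkage, whereas compound 2 has the five-membered ring core, so no single-point step between measured compounds is available.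

Compound 4 `COc1cc(C2=NN(C(C)=O)C(c3cccc(OC)c3OC)O2)cc(OC)c1OC` keeps the core of compound 2 and differs from it in one place: 2,3-dimethoxyphenyl in place of 2,6-dichlorophenyl on a saturated ring carbon. The measured compounds give no guide to what this exchange does on that saturated ring carbon. With compound 2 near zero at -2.2%, a small upward step is expected for compound 4, a number 12.2 percentage points higher from compound 2 to compound 4 (beyond the scatter), though a step of no size beyond the scatter is about as likely. Compound 4 is estimated at 10%, within -10% to 35%.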

Compound 4, a percentage reported as inhibition, at one concentration (the size of the read-out at that concentration, not a potency): 58.2%
Compound 4: middle estimate off by 48.2 percentage points, on the low side, and the stated range ends below it.
By their numbers in this assay, from the lowest: compound 2; then compounds 1, 3 and 4 (each within the scatter of the next, the first and the last beyond it).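

The saturated ring carbon is a position that strongly governs the read-out in this core: in this assay, 2,3-dimethoxyphenyl in place of 2,6-dichlorophenyl gives a number 60.4 percentage points higher from compound 2 to compound 4 (beyond the scatter), a large step. The near-zero reading of compound 2 is therefore not a fixed feature of the core, as compound 4 keeps that core and differs only in this aryl group. The data give no explanation for the size of this step.

The exchange removes both chlorines and adds both methoxy groups at once, so the contribution of each group and of their placement cannot be separated. Open questions are how 2,6-dimethoxyphenyl, a single methoxy group or a phenyl ring bearing an amine or a carboxylic acid would read at this carbon, and whether a longer acyl chain could replace the acetyl group.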